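The source may report more compounds than this note shows. Statements on the series, on what has been measured and on what is new or still open speak of the compounds shown alone.

Working notes on the series in an ADME assay on MT4 cells (Homo sapiens) for activation, read by MTT assay; on this read-out higher numbers stand for lower toxicity in this test and lower numbers for higher toxicity in this test.

Compound 1, `CCCCSc1nc(Cc2c(F)cccc2Cl)cc(=O)[nH]1`, gives only a limit, > 76000 nM. Compound 2, `O=c1cc(Cc2c(F)cccc2Cl)nc(SC2CCCC2)[nH]1`, likewise gives only a limit, > 74000 nM. The change between them is cyclopentyl in place of butyl on a sulfur, and the step that the two limits leave unreadable from compound 1 to compound 2 is therefore not readable in size, because both values rest on the limits the limit of > 76000 nM in this assay, at which 1 of the 3 values shown sits, and (the limit of > 74000 nM in this assay, at which 1 of the 3 values shown sits).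

Compound 3, `CCCCSc1nc(C(C)c2c(F)cccc2Cl)c(C)c(=O)[nH]1`, again returns only a limit, > 1500 nM, which is the limit of > 1500 nM in this assay, at which 1 of the 3 values shown sits; the difference between the core of compound 3 and the core of compound 1 is not broken down here.

Compound 4, `Cc1c(C(C)c2c(F)cccc2Cl)nc(SC2CCCC2)[nH]c1=O`, carries the same change relative to compound 3 as compound 2 does relative to compound 1, namely (cyclopentyl in place of butyl on a sulfur), at the same place in both pairs. As the earlier step that the two limits leave unreadable from compound 1 to compound 2 gives no readable size, the expectation for compound 4 rests only on the limit of compound 3, > 1500 nM, and on the limits of compound 1 and compound 2. The step expected from compound 3 to compound 4 in this assay is a step that the limit leaves unreadable from compound 3 to compound 4, with a limit likely again. Compound 4 is thus estimated at 40000 nM, within 3000 nM to 150000 nM.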

Compound 4, half-maximal cytotoxic concentration: > 15000 nM
Compound 4 gave a limit, no number (the forecaster's own chance of this, stated with the estimate: 80%); the middle value is on the limit's open side.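

In this assay, no step can be read from compound 3 to compound 4, as both return only limits, and the same holds for compound 1 and compound 2. The compounds shown leave open how cyclopentyl and butyl on the sulfur compare in either pair, and where any of these four compounds would give an actual number.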